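This account rests on a few compounds, and the source may have more. Where it says the series, first, only, none or still open, it means among the compounds named here.

Compound 3 `CCCOC(=O)C(O)Cn1cnc2c(N)ncnc21` stands in a functional assay on PRK cells (Oryctolagus cuniculus) for cytotoxicity (a higher number here means that more compound is tolerated, a lower number that less compound is tolerated), at 100 ug/mL, level with compound 2 `Nc1ncnc2c1ncn2CC(O)C(=O)OC1CCCCC1`, which gives 100 ug/mL in this assay. Compound 1 `COC(=O)C(O)Cn1cnc2c(N)ncnc21` gives only a limit in this assay, > 400 ug/mL. The change to compound 4 `CCOC(=O)C(O)Cn1cnc2c(N)ncnc21` is hydrogen in place of methyl on a saturated chain carbon, two bonds along the chain from an oxygen next to a carbonyl group. For the measured compounds named here, two measured steps bear on it: an at least 4.0-fold lower number from compound 1 to compound 3 (0.60 log units; beyond the scatter), while no change at the digits printed from compound 2 to compound 3 (within the scatter). Compound 4 thus carries an ethyl chain, sitting between the methyl of compound 1 and the propyl of compound 3, so a partial return towards the higher number of compound 1 is expected, smaller than an at least 4.0-fold lower number from compound 1 to compound 3 (0.60 log units; beyond the scatter). Compound 4 is therefore expected to show a 2.0-fold higher number from compound 3 to compound 4 (0.30 log units; within the scatter), giving an estimated 200 ug/mL, with a range from 100 ug/mL to 400 ug/mL.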

Compound 4, minimum cytotoxic concentration: > 400 ug/mL
Compound 4 gave a limit, no number; the forecaster's own chance of this, stated with the estimate: 20%; middle value at least 2.0-fold (0.30 log units) from the limit.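

In this assay, hydrogen in place of methyl on a saturated chain carbon, two bonds along the chain from an oxygen next to a carbonyl group, brings an at least 4.0-fold higher number from compound 3 to compound 4 (0.60 log units; beyond the scatter), so a single carbon here separates the propyl and ethyl chains. Ethyl in place of cyclohexyl likewise brings an at least 4.0-fold higher number from compound 2 to compound 4 (0.60 log units; beyond the scatter). Compound 4 and compound 1 both give only a limit, so the step between them cannot be read: the limit of > 400 ug/mL in this assay, at which 2 of the 4 values shown sit.

As far as these compounds go, whether a longer chain, such as butyl, stays level with compound 3 remains open, as does the effect of a branched isopropyl chain on the same oxygen.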